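Swapping furan-2-yl for thiophen-2-yl in compound 3

The source may hold more compounds than are shown below. What is called first, only, known or untested is meant among the compounds shown, and "the series" means these compounds.

Compound 1 `CNc1ncnc2c1c(-c1ccco1)cn2[C@@H]1O[C@H](CO)[C@@H](O)[C@H]1O` gives 5000 nM as a number
Compound 2 `O=c1[nH]cnc2c1c(-c1cc3ccccc3o1)cn2[C@@H]1O[C@H](CO)[C@@H](O)[C@H]1O` gives > 20000 nM as a limit
Compound 3 `Nc1nc(N)c2c(-c3ccco3)cn([C@@H]3O[C@H](CO)[C@@H](O)[C@H]3O)c2n1` gives > 20000 nM as a limit

In a functional assay on HeLa S3 cells (Homo sapiens) for antiproliferative activity, read by XTT assay, with a stated time of 72 h (a higher number here means a weaker inhibitor, a lower number a stronger inhibitor), compound 1 gives 5000 nM and is the only one of the three with a true number. Compound 3 stands at > 20000 nM in this assay and this is a limit, not a number. Compound 2 reads > 20000 nM and this too is a limit. Compound 3 therefore sits at the limit of > 20000 nM in this assay, at which 2 of the 3 values shown sit, and has no exact place on the scale.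

Compound 4 `Nc1nc(N)c2c(-c3cccs3)cn([C@@H]3O[C@H](CO)[C@@H](O)[C@H]3O)c2n1` keeps the core of compound 3 and carries thiophen-2-yl in place of furan-2-yl on an aromatic carbon, the difference being thiophen-2-yl in place of furan-2-yl on an aromatic carbon and nothing else. Among the compounds with values here, no two measured compounds differ in one place only, so the data hold no direct measure of this swap.

The expectation rests on compound 3 with its limit of > 20000 nM and on the close match of the two groups in what is counted. The expected step is a number no higher from compound 3 to compound 4 (the limit leaves the size open) in this assay and it is not expected to go beyond the scatter in either direction. Compound 4 is estimated at 20000 nM with an expected range from 6000 nM to 40000 nM and may well return only a limit.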

Compound 4, half-maximal inhibitory concentration: > 20000 nM
Compound 4: a limit, no number; the forecaster's own chance of this, stated with the estimate: 65%; the middle value lies on the limit itself.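

Within the data shown here, compound 3 and compound 4 both return only a limit in this assay, so no step between them can be read, and the swap of furan-2-yl for thiophen-2-yl stays unmeasured here: the limit of > 20000 nM in this assay, at which 3 of the 4 values shown sit. The compounds shown leave open where on the scale compound 3 and compound 4 truly lie, and whether the two groups differ at all.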